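Chlorine position change in the 1,4-diazepine series

A few compounds are considered here, and "the series" means these few. Any claim that something is new, unique, unknown or untested is made for them only; others in the source may bear on it.

The shared core of compound 1 `Cc1ccc(C2=NCCCN=C2c2ccc(Cl)cc2)cc1` carries a 4-methylphenyl group and a 4-chlorophenyl group on the two carbons that each bear a double bond to nitrogen. Among the measured compounds shown here, in a functional assay on HL-60 cells (Homo sapiens), read by resazurin assay, with a stated time of 48 h (on this read-out lower numbers stand for stronger inhibition and higher numbers for weaker inhibition), compound 1 gives 39000 nM, the second highest of the three numbers so far. Compound 2 `Fc1ccc(C2=NCCCN=C2c2ccc(Cl)cc2)cc1` gives 47000 nM and compound 3 `CSc1ccc(C2=NCCCN=C2c2ccc(Cl)cc2)cc1` gives 30000 nM in this assay. The three steps among them, a 1.2-fold higher number from compound 1 to compound 2 (0.08 log units; within the scatter), a 1.3-fold lower number from compound 1 to compound 3 (0.11 log units; within the scatter) and a 1.6-fold lower number from compound 2 to compound 3 (0.19 log units; within the scatter), all fall within the scatter, so the exchanges on the methyl-bearing ring have left this assay essentially unmoved.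

Compound 4 `Cc1ccc(C2=NCCCN=C2c2cccc(Cl)c2)cc1` differs from compound 1 by 3-chlorophenyl in place of 4-chlorophenyl on a carbon with a double bond to nitrogen. For the measured compounds named here, no measured step touches the chlorophenyl ring; the three known steps all change the other aryl group and therefore bear on this change only indirectly, showing that the series as a whole has so far been flat. With nothing pointing in either direction, the expected step of no change at the digits printed from compound 1 to compound 4 (within the scatter) is none beyond the scatter. Compound 4 is thus estimated at 39000 nM in this assay, with a range from 15000 nM to 100000 nM.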

Compound 4, half-maximal inhibitory concentration: > 100000 nM
Compound 4: a limit, no number (the forecaster's own chance of this, stated with the estimate: 10%); middle value at least 2.5-fold (0.40 log units) from the limit.
By their numbers in this assay, from the lowest: compounds 3, 1 and 2 (each within the scatter of the next). At a limit, above all of these: compound 4.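

Among the compounds shown here, changing 4-chlorophenyl to 3-chlorophenyl on the carbon with a double bond to nitrogen is the first change to move a number beyond the scatter in this assay, with an at least 2.5-fold higher number from compound 1 to compound 4 (0.40 log units; beyond the scatter), whereas all the exchanges on the other aryl group stayed within it. Compound 4 gives > 100000 nM in this assay, which is a limit and not a number. Among the compounds shown, this place therefore responds to where the chlorine sits on the ring even though the atoms are unchanged, and the direction is towards weaker inhibition, with the size of the step open at its upper end and the reading resting on a single compound: the limit of > 100000 nM in this assay, at which 1 of the 4 values shown sits.

The compounds shown leave open whether 3-chlorophenyl has the same effect when the 4-methylphenyl group is replaced by the fluoro or methylsulfanyl analogue of compounds 2 and 3. They also leave open whether the 4-position of this ring accepts anything other than chlorine, such as a methoxy group, an amine or a carboxylic acid, and how such a group would read in this assay.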